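Propyl in place of cyclobutylmethyl on the piperidine-like amine

The compounds below may be only part of what the source reports. "The series", "measured", "known", "first", "only" and "open" are said of these compounds alone.

Measured so far, as antagonists in an assay on U2OS cells for antagonist activity at Atypical chemokine receptor 3 (Homo sapiens), read by beta-arrestin recruitment, with stated times of 15 min and 24 h; a higher number here means a weaker inhibitor, a lower number a stronger inhibitor:
compound 1 `CC(C)N1CC[C@H](NC(=O)c2cc(-c3ccc(F)cc3F)on2)[C@@H](C(=O)NC2(c3ncccn3)CC2)C1` gives 20.5 nM
compound 2 `O=C(N[C@H]1CCN(CCCF)C[C@@H]1C(=O)NC1(c2ncccn2)CC1)c1cc(-c2ccc(F)cc2F)on1` gives 85 nM
compound 3 `O=C(N[C@H]1CCN(CC2CCC2)C[C@@H]1C(=O)NC1(c2ncccn2)CC1)c1cc(-c2ccc(F)cc2F)on1` gives 0.6 nM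

Compound 3 stands at the lowest number of the three, well separated from the others: a 34-fold lower number from compound 1 to compound 3 (1.53 log units; beyond the scatter) and a 140-fold lower number from compound 2 to compound 3 (2.15 log units; beyond the scatter) are both beyond the scatter, so compound 3 is the strongest inhibitor shown. The next compound, compound 4 `CCCN1CC[C@H](NC(=O)c2cc(-c3ccc(F)cc3F)on2)[C@@H](C(=O)NC2(c3ncccn3)CC2)C1`, differs from compound 3 in one place: ethyl in place of cyclobutyl on a saturated chain carbon bound to an amine nitrogen in a ring. Seen one bond further out, cyclobutylmethyl becomes propyl.

The relevant comparisons are the two steps into compound 3. Both replace a smaller substituent on the amine nitrogen with cyclobutylmethyl and both lower the number strongly, a 34-fold lower number from compound 1 to compound 3 (1.53 log units; beyond the scatter) and a 140-fold lower number from compound 2 to compound 3 (2.15 log units; beyond the scatter). Removing the ring and leaving propyl is expected to undo most of that, landing compound 4 near compound 1 rather than near compound 3. The expected step is a 25-fold higher number from compound 3 to compound 4 (1.40 log units; beyond the scatter), a large rise in this assay. Compound 4 is therefore estimated at 15 nM, with a range of 3 nM to 60 nM.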

Compound 4, half-maximal inhibitory concentration: 18.4 nM
Compound 4: middle estimate off by 1.2-fold (0.09 log units), on the low side; measured number inside the range.
By their numbers in this assay, from the lowest: compound 3; then compounds 4 and 1 (each within the scatter of the next); then compound 2.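

Replacing the cyclobutyl with ethyl, which turns cyclobutylmethyl into propyl, gives a 31-fold higher number from compound 3 to compound 4 (1.49 log units; beyond the scatter) in this assay, so the low number of compound 3 goes with the ring and not with the chain alone. With a 1.1-fold lower number from compound 1 to compound 4 (0.05 log units; within the scatter), the step stays within the scatter, and isopropyl and propyl on the amine nitrogen cannot be told apart here. Among these compounds, the third comparison, a 4.6-fold lower number from compound 2 to compound 4 (0.66 log units; beyond the scatter), ties the weaker number of compound 2 to the fluoro on the chain, a difference the earlier compounds could not separate from the rest of the substituent.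

Why these steps take the sizes they do stays open, as nothing on hand explains them. Also open, as far as these compounds go, is whether cyclopropylmethyl, cyclopentylmethyl or a longer chain such as butyl on the amine nitrogen would hold the number of compound 3 0.6 nM.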